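This account rests on a few compounds, and the source may have more. Where it says the series, first, only, none or still open, it means among the compounds named here.

Compound 3 `C=CC(=O)Nc1cccc(NC(=O)CSc2nc(Nc3ccccc3Cl)c3ccccc3n2)c1` was tested in a functional assay on NCI-H1975 cells (Homo sapiens) for inhibition, read by MTT assay, with a stated time of 72 h (on this read-out lower numbers stand for stronger inhibition and higher numbers for weaker inhibition), where compound 3 gives 10000 nM. Two related compounds give numbers in the same region: compound 1 `O=C(CSc1nc(Nc2ccccc2)c2ccccc2n1)Nc1ccccc1F` gives 9350 nM and compound 2 `O=C(CSc1nc(Nc2ccccc2)c2ccccc2n1)Nc1ccc(F)cc1` gives 16500 nM, and all three numbers lie within the usual scatter of one another, so none of them can be called stronger or weaker than the others. The unmeasured compound 4 `C=CC(=O)Nc1cccc(NC(=O)CSc2nc(Nc3cccc(OC)c3)c3ccccc3n2)c1` differs from compound 3 in one place: 3-methoxyphenyl in place of 2-chlorophenyl on a nitrogen on an aromatic ring. Within the data shown here, the only measured step, a 1.8-fold higher number from compound 1 to compound 2 (0.25 log units; within the scatter), changes a group on an amide-type nitrogen rather than on the nitrogen on an aromatic ring, so it does not bear directly on this change; it shows only that exchanging one substituted phenyl for another at a different site left the number within the scatter. With nothing measured at the site of this change, the expected step of no change at the digits printed from compound 3 to compound 4 (within the scatter) is none beyond the scatter. Compound 4 is therefore estimated at 10000 nM, with a range from 4000 nM to 25000 nM.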

Compound 4, half-maximal inhibitory concentration: 7940 nM
For compound 4 the middle estimate is 1.3-fold (0.10 log units) above the measured one, within the range that was stated.
By their numbers in this assay, from the lowest: compounds 4, 1, 3 and 2 (each within the scatter of the next, the first and the last beyond it).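

Among these compounds, this is the only measured step at this site: 3-methoxyphenyl in place of 2-chlorophenyl on a nitrogen on an aromatic ring gives a 1.3-fold lower number from compound 3 to compound 4 (0.10 log units; within the scatter) in this assay on this read-out. The earlier compounds shown here held no pair that differed here, and this one shows that a phenyl carrying chlorine and a phenyl carrying methoxy can be exchanged at this site without a number that stands clear of the scatter. Nothing measured here explains why the two groups read alike.

From the compounds shown here alone, both groups are substituted phenyl rings, so what a simple alkyl chain, an amine or a carboxylic acid would do on that nitrogen stays open. Also open, going by these compounds, is whether 3-methoxyphenyl would read the same on the core of compound 1, which carries a different group on its amide-type nitrogen.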